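Swapping a chloro-benzyl for a cyano-benzyl on the triazole

The compounds below may be only part of what the source reports. "The series", "measured", "known", "first", "only" and "open" are said of these compounds alone.

Three compounds share one core, a chromenone linked through an ether and a triazole to a benzyl group, and differ only in that benzyl group. In a functional assay on QGY7701 cells (Homo sapiens) for cytotoxicity, read by MTT assay, with a stated time of 48 h (a higher number here means a weaker inhibitor, a lower number a stronger inhibitor), compound 1 `Cc1ccc(Cn2cc(COc3ccc4c(=O)ccoc4c3)nn2)cc1` gives 68500 nM. Compound 2 `O=c1ccoc2cc(OCc3cn(Cc4ccc(Cl)cc4Cl)nn3)ccc12` gives 13300 nM in this assay, and compound 3 `O=c1ccoc2cc(OCc3cn(Cc4cccc(Cl)c4)nn3)ccc12` gives 28400 nM in this assay. Among these three numbers compound 3 holds the second highest, sitting a 2.1-fold higher number from compound 2 to compound 3 (0.33 log units; beyond the scatter) and a 2.4-fold lower number from compound 1 to compound 3 (0.38 log units; beyond the scatter).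

Compound 4 `N#Cc1ccc(Cn2cc(COc3ccc4c(=O)ccoc4c3)nn2)cc1` is the next step: 4-cyanophenyl in place of 3-chlorophenyl on a saturated chain carbon bound to an aromatic nitrogen. Among the measured compounds shown here, no measured pair carries a nitrile, so the only guidance is the modest movement seen when the benzyl substituent changed before, namely a 5.2-fold lower number from compound 1 to compound 2 (0.71 log units; beyond the scatter) and a 2.4-fold lower number from compound 1 to compound 3 (0.38 log units; beyond the scatter). Those steps were small, so for compound 4 a step of a 1.1-fold higher number from compound 3 to compound 4 (0.05 log units; within the scatter) is expected, barely beyond the scatter, if at all. Compound 4 is therefore estimated at 32000 nM in this assay. The range for compound 4 is expected to run from 12000 nM to 80000 nM.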

Compound 4, half-maximal inhibitory concentration: > 100000 nM
Compound 4 was reported as a limit; the forecaster's own chance of this, stated with the estimate: 10%; at least 3.1-fold (0.49 log units) between middle value and limit.
By their numbers in this assay, from the lowest: compound 2; then compound 3; then compound 1. At a limit, above all of these: compound 4.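

Compound 4 is reported only as a limit, not as a number: the limit of > 100000 nM in this assay, at which 1 of the 4 values shown sits. The earlier changes on this saturated chain carbon bound to an aromatic nitrogen all gave measurable numbers, but the nitrile-bearing benzyl group separates clearly from both chlorinated compounds, with an at least 3.5-fold higher number from compound 3 to compound 4 (0.54 log units; beyond the scatter) and an at least 7.5-fold higher number from compound 2 to compound 4 (0.87 log units; beyond the scatter). Against the methyl group the reading is much weaker, with an at least 1.4-fold higher number from compound 1 to compound 4 (0.16 log units; that floor lies within the scatter), so cyano in place of methyl shows no firm change.

From the compounds shown here alone, how far compound 4 lies past its limit remains open. Also open, going by these compounds, is whether the loss follows the nitrile itself or its place on the ring, a question that a 3-cyanophenyl or 4-chlorophenyl group could address, and whether a 4-aminophenyl group would behave like the 4-methylphenyl or the 4-cyanophenyl.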